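The compounds below may be only part of what the source reports. "The series", "measured", "known", "first", "only" and "open" are said of these compounds alone.

Measured so far:
- compound 1, `NC(=O)c1c(NC(=O)c2ccccc2Cl)sc2c1CCNC2`: 45000 nM
- compound 2, `NC(=O)c1c(NC(=O)c2ccc(C(F)(F)F)cc2)sc2c1CCN(Cc1c(Cl)cccc1Cl)C2`: a limit, > 50000 nM
- compound 3, `Cc1ccc(C(=O)Nc2sc3c(c2C(N)=O)CCN(Cc2c(Cl)cccc2Cl)C3)cc1`: 47400 nM

In a functional assay on HeLa cells (Homo sapiens) for antiproliferative activity, with a stated time of 24 h (on this read-out higher numbers stand for weaker inhibition and lower numbers for stronger inhibition), compound 1 gives 45000 nM, the lowest of the two numbers shown, and compound 3 gives 47400 nM, a value within the usual scatter of compound 1. For compound 2 the result is only a limit of the assay, > 50000 nM, as noted in the limit of > 50000 nM in this assay, at which 1 of the 3 values shown sits.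

Compound 4, `NC(=O)c1c(NC(=O)c2ccccc2Cl)sc2c1CCN(C(=S)Nc1ccccc1)C2`, differs from compound 1 by a group of 9 heavy atoms (7 carbon, 1 nitrogen, 1 sulfur; one six-membered aromatic ring of carbon only) in place of a hydrogen atom, on an amine nitrogen in a ring

Within the data shown here, the one measured step, an at least 1.0-fold lower number from compound 2 to compound 3 (0.02 log units; that floor lies within the scatter), concerns a different place in the molecule, a substituent on an aromatic carbon, and stayed within the scatter; no measured step touches the ring amine nitrogen alone. Compounds 2 and 3 carry a substituent on that nitrogen yet sit no lower than compound 1. No change beyond the scatter is therefore expected from compound 1 to compound 4, a step of no change at the digits printed from compound 1 to compound 4 (within the scatter). Compound 4 is estimated at 45000 nM, between 18000 nM and 110000 nM.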

Compound 4, half-maximal inhibitory concentration: 46700 nM
Estimate against measurement, compound 4: 1.0-fold (0.02 log units) below, and the stated range covers the measured number.
By their numbers in this assay, from the lowest: compounds 1, 4 and 3 (each within the scatter of the next). At a limit, above all of these: compound 2.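

Among these compounds, this is the first measured step that touches only the amine nitrogen in the ring: in this assay, a 1.0-fold higher number from compound 1 to compound 4 (0.02 log units; within the scatter). Putting a group of 9 heavy atoms, with its six-membered aromatic ring, in place of the hydrogen atom therefore brings no gain in inhibition here, and the position accepts this large group without a change beyond the scatter. Compound 2 remains a limit, not a number: the limit of > 50000 nM in this assay, at which 1 of the 4 values shown sits.

Still open, as far as these compounds go, is whether a carboxylic acid or a longer carbon chain on that nitrogen would move the number beyond the scatter. No step shown yet does so, so what strengthens inhibition in this series remains unknown.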